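A few compounds are considered here, and "the series" means these few. Any claim that something is new, unique, unknown or untested is made for them only; others in the source may bear on it.

Measured in an ADME assay on MT4 cells (Homo sapiens) for cytotoxicity, read by MTT assay; a higher number here means that more compound is tolerated, a lower number that less compound is tolerated:
- compound 1 `Cc1ccc(NC(=O)CSc2nncnc2-c2cccc3ccccc23)c(Br)c1`: 166000 nM
- compound 2 `O=C(CSc1nncnc1-c1cccc2ccccc12)Nc1ccccc1Cl`: 63000 nM

Compound 2 is the lower of the two, at 63000 nM. Compound 3 `O=C(CSc1nncnc1-c1cccc2ccccc12)Nc1ccc([N+](=O)[O-])cc1Cl` carries nitro in place of hydrogen on an aromatic carbon, meta to a chloro group and para to a large group, so 2-chlorophenyl becomes 2-chloro-4-nitrophenyl.

Going by the values given here, only one measured step bears on this change: a 2.6-fold lower number from compound 1 to compound 2 (0.42 log units; beyond the scatter). It also alters the group on the amide-type nitrogen, but it involves no nitro group, so it suggests a likely size and gives no direction. A step beyond the scatter is therefore not expected, although a modest move either way remains possible.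

The expected step is a 1.3-fold lower number from compound 2 to compound 3 (0.10 log units; within the scatter). For compound 3 the estimated value is 50000 nM, with an expected range of 16000 nM to 160000 nM.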

Compound 3, half-maximal cytotoxic concentration: 150000 nM
The estimate for compound 3 lay 3.0-fold (0.48 log units) below the measured number; low and high end bracket the measured number.
By their numbers in this assay, from the lowest: compound 2; then compounds 3 and 1 (each within the scatter of the next).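

On the 2-chlorophenyl group, nitro in place of hydrogen on an aromatic carbon, meta to a chloro group and para to a large group, gives in this assay a 2.4-fold higher number from compound 2 to compound 3 (0.38 log units; beyond the scatter) and so fixes a direction at this position, towards more compound tolerated. Going by these compounds alone, the 2-chloro-4-nitrophenyl and 2-bromo-4-methylphenyl groups on the amide-type nitrogen are not separated in this assay, with a 1.1-fold lower number from compound 1 to compound 3 (0.04 log units; within the scatter), which leaves compound 2 as the one member set apart from the other two. Nothing measured here accounts for the nitro step.

From the compounds shown here alone, whether an amine or a carboxylic acid on the same aromatic carbon would move the number in the same direction stays open. Also open, going by these compounds, is whether the nitro step carries over when bromo stands in place of the chloro group.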